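The source may report more compounds than this note shows. Statements on the series, on what has been measured and on what is new or still open speak of the compounds shown alone.

Compound 1 `CN1[C@@H]2c3[nH]c4ccccc4c3C[C@H]1[C@H](C#N)N1[C@@H](CN3C(=O)c4ccccc4C3=O)c3[nH]c4ccccc4c3C[C@@H]21`: 80 nM in a functional assay on A2780 cells (Homo sapiens) for cytotoxicity, read by MTT assay, with a stated time of 72 h; on this read-out lower numbers stand for stronger inhibition and higher numbers for weaker inhibition
Compound 2 `CCc1ccc(C(=O)NC[C@H]2c3[nH]c4ccccc4c3C[C@H]3[C@H]4c5[nH]c6ccccc6c5C[C@@H]([C@H](C#N)N23)N4C)cc1`: 670 nM
Compound 3 `CN1[C@@H]2c3[nH]c4ccccc4c3C[C@H]1[C@H](C#N)N1[C@@H](CNC(=O)c3ccc4ccccc4c3)c3[nH]c4ccccc4c3C[C@@H]21`: 1030 nM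

These three compounds share one core and differ only in the group attached on a saturated chain carbon bound to a saturated ring carbon. In this assay compound 1 gives the lowest number of the three, with compound 2 nearest and compound 3 furthest. Compound 4 `CN1[C@@H]2c3[nH]c4ccccc4c3C[C@H]1[C@H](C#N)N1[C@@H](CNC(=O)c3cc4ccccc4[nH]3)c3[nH]c4ccccc4c3C[C@@H]21` carries the change (a group of 12 heavy atoms (9 carbon, 2 nitrogen, 1 oxygen; one five-membered aromatic ring with 1 hetero atom, one six-membered aromatic ring of carbon only) in place of a group of 11 heavy atoms (8 carbon, 1 nitrogen, 2 oxygen; one five-membered non-aromatic ring with 1 hetero atom, one six-membered aromatic ring of carbon only), on a saturated chain carbon bound to a saturated ring carbon). The step that bears most on it is an 8.4-fold higher number from compound 1 to compound 2 (0.92 log units; beyond the scatter), where an amide-linked aromatic group replaced the same leaving group; the further step a 1.5-fold higher number from compound 2 to compound 3 (0.19 log units; within the scatter) shows that swapping one aromatic group on the carbonyl carbon for another changed little. A rise of similar size is therefore expected: a 10-fold higher number from compound 1 to compound 4 (1.00 log units; beyond the scatter). Compound 4 is estimated at 800 nM, with a range of 300 nM to 2200 nM.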

Compound 4, half-maximal inhibitory concentration: 7100 nM
Estimate against measurement, compound 4: 8.9-fold (0.95 log units) below; the whole stated range lies below it.
By their numbers in this assay, from the lowest: compound 1; then compounds 2 and 3 (each within the scatter of the next); then compound 4.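

At this position the choice of aromatic group on the carbonyl carbon can matter: 1H-indol-2-yl gives an 11-fold higher number from compound 2 to compound 4 (1.03 log units; beyond the scatter) and a 6.9-fold higher number from compound 3 to compound 4 (0.84 log units; beyond the scatter), although 4-ethylphenyl and naphthalen-2-yl lie within the scatter of each other. Replacing the group carried by compound 1 with the indole amide gives an 89-fold higher number from compound 1 to compound 4 (1.95 log units; beyond the scatter), so this amide sits well apart from the other two. No measurement shown explains why the indole amide stands apart. The compounds shown leave open how 1-methyl-1H-indol-2-yl on the carbonyl carbon would compare, and so whether the step depends on the indole ring hydrogen.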